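Sulfonyl anilino series: cytotoxicity notes and one open compound

A few compounds are considered here, and "the series" means these few. Any claim that something is new, unique, unknown or untested is made for them only; others in the source may bear on it.

Measured so far in a functional assay on HCT-116 cells (Homo sapiens) for cytotoxicity, read by MTT assay, with a stated time of 72 h; on this read-out higher numbers stand for weaker inhibition and lower numbers for stronger inhibition:
Compound 1 `Cc1ccc(S(=O)(=O)c2nc3ccccc3nc2Nc2ccc(Cl)cc2)cc1` gives 2050 nM
Compound 2 `Cc1ccc(S(=O)(=O)c2nc3ccccc3nc2Nc2ccc(C(F)(F)F)cc2)cc1` gives 950 nM
Compound 3 `O=S(=O)(c1ccc(Br)cc1)c1nc2ccccc2nc1Nc1ccc(Cl)cc1` gives 10600 nM

Three compounds share one core and differ only at the two outer aromatic rings. Compound 3 stands at the highest number of the three in this assay. The larger recorded step is a 5.2-fold higher number from compound 1 to compound 3 (0.71 log units; beyond the scatter), and the difference behind it is bromo in place of methyl on an aromatic carbon. The smaller recorded step is a 2.2-fold lower number from compound 1 to compound 2 (0.33 log units; beyond the scatter), and the difference behind it is trifluoromethyl in place of chloro on an aromatic carbon.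

Compound 4 `O=S(=O)(c1ccc(Br)cc1)c1nc2ccccc2nc1Nc1ccc(C(F)(F)F)cc1` is not yet measured. It differs from compound 3 by trifluoromethyl in place of chloro on an aromatic carbon. This is the same change that is seen between the first two compounds; it occurs twice among the compounds here, once measured and once open. The cores of the two pairs differ by bromo in place of methyl on an aromatic carbon. The place of the change is described in the same words in both pairs, so it is taken as the same change, not only the same kind.

Among the compounds with values here, for compound 4 a step of roughly the earlier size is expected, a 2.2-fold lower number from compound 3 to compound 4 (0.34 log units; beyond the scatter), resting on the one measured instance of this change, a 2.2-fold lower number from compound 1 to compound 2 (0.33 log units; beyond the scatter). Whether the change carries over unaltered onto the core of compound 3 is not tested by anything else in the set. Compound 4 is therefore estimated at about 4800 nM in this assay, expected to fall between 2000 nM and 12000 nM.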

Compound 4, half-maximal inhibitory concentration: 2610 nM
Beside the measured number, compound 4's estimate is 1.8-fold (0.26 log units) above it, and the stated range covers the measured number.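

In this assay, trifluoromethyl in place of chloro again gives a lower number on the core of compound 3, with a 4.1-fold lower number from compound 3 to compound 4 (0.61 log units; beyond the scatter), and the size of this step cannot be told apart from the earlier one: the same change on two cores in this assay, a 2.2-fold lower number (0.33 log units; beyond the scatter) from compound 1 to compound 2 and a 4.1-fold lower number (0.61 log units; beyond the scatter) from compound 3 to compound 4, 1.9-fold (0.27 log units) apart, within the scatter of two such steps. Read the other way around the same four compounds, bromo in place of methyl again gives a higher number, with a 2.7-fold higher number from compound 2 to compound 4 (0.44 log units; beyond the scatter), and this step likewise agrees with its earlier counterpart: the same change on two cores in this assay, a 5.2-fold higher number (0.71 log units; beyond the scatter) from compound 1 to compound 3 and a 2.7-fold higher number (0.44 log units; beyond the scatter) from compound 2 to compound 4, 1.9-fold (0.27 log units) apart, within the scatter of two such steps. This supports carrying either change between these two cores in this assay, with direction kept and size agreeing within the scatter, but it does not prove that the steps are equal, and a single set of four compounds says nothing about other cores or about why the numbers move.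

The compounds shown leave open whether the same steps hold when a nitrile, a methoxy group or an amine stands in place of the chloro or trifluoromethyl, or when a carboxylic acid or a longer chain stands in place of the methyl or bromo. They also leave open whether the agreement between the two cores extends beyond this assay to other cell lines.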